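Swapping propoxy for phenoxy: an expected plasma level

The source may hold more compounds than are shown below. What is called first, only, known or untested is meant among the compounds shown, and "the series" means these compounds.

Compound 1 `CCOC(=O)c1c(-c2cccc(-c3ccccc3)c2)[nH]c2cc(OC)ccc2c1=O`: 430 nM
Compound 2 `CCCOc1cccc(-c2[nH]c3cc(OC)ccc3c(=O)c2C(=O)OCC)c1`: 1800 nM

Both values come from an in vivo ADME assay on the whole organism (strain CD1) for pharmacokinetics, with Mus musculus as the target, at a dose of 200 mg/kg by the oral route; a lower number here means less compound in the circulation, a higher number more compound in the circulation at the dose given. Among the measured compounds shown here, compound 2 has the higher of the two numbers, and compound 1 is its only measured neighbour. Compound 3 `CCOC(=O)c1c(-c2cccc(Oc3ccccc3)c2)[nH]c2cc(OC)ccc2c1=O` has not yet been measured. It differs from compound 2 by phenyl in place of propyl on an oxygen on an aromatic ring.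

For the measured compounds named here, one measured step bears on this change: a 4.2-fold higher number from compound 1 to compound 2 (0.62 log units; beyond the scatter). That modest step put propoxy in place of phenyl on an aromatic carbon, so it is a related change but not the same one. Read in reverse, it points toward a lower number, though a single step is thin evidence and the phenyl here sits on oxygen. The estimated change is a 2.3-fold lower number from compound 2 to compound 3 (0.35 log units; beyond the scatter). Compound 3 is expected at about 800 nM, with an estimated range of 250 nM to 2500 nM.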

Compound 3, maximal plasma concentration: 400 nM
For compound 3 the middle estimate is 2.0-fold (0.30 log units) above the measured one; the range from low to high includes it.
By their numbers in this assay, from the lowest: compounds 3 and 1 (each within the scatter of the next); then compound 2.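

In this assay, the step of a 4.5-fold lower number from compound 2 to compound 3 (0.65 log units; beyond the scatter) shows that the higher level of compound 2 does not carry over when an aromatic ring takes the place of the chain on the same oxygen. The step of a 1.1-fold lower number from compound 1 to compound 3 (0.03 log units; within the scatter) adds that, for the aromatic ring, the oxygen link makes no readable difference: phenoxy and phenyl on an aromatic carbon cannot be told apart here. Among these three compounds, only the propoxy group stands apart, with both ring-bearing compounds sitting together well under compound 2.

Going by these compounds, whether a longer chain such as butoxy, or an amine at the end of the propoxy chain, would hold or raise the level remains open. The data offer no measurement that explains these differences.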